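A few compounds are considered here, and "the series" means these few. Any claim that something is new, unique, unknown or untested is made for them only; others in the source may bear on it.

Three compounds have been measured in a functional assay on CHO cells for agonist activity at adenosine receptor A1 (Homo sapiens), read by fluorescence and ERK phosphorylation, with stated times of 30 min and 1.5 h, tested at 3 uM; a higher number here means a stronger effect of the compound at the concentration tested, a lower number a weaker effect:

compound 1 `Nc1scc(-c2cccc(C(F)(F)F)c2)c1C(=O)c1ccccc1` gives 83%
compound 2 `Nc1scc(-c2cccc(C(F)(F)F)c2)c1C(=O)c1ccc(Cl)cc1` gives 64%
compound 3 `Nc1scc(-c2ccc(F)cc2)c1C(=O)c1ccc(Cl)cc1` gives 62%

Compound 2 stands second highest of these three numbers. Its nearest neighbour is compound 3, whose value lies within the usual scatter of compound 2, so the two cannot be told apart. Within the data shown here, its furthest neighbour is compound 1, and the single measured step that links them, a number 19 percentage points lower from compound 1 to compound 2 (beyond the scatter), lies beyond the scatter.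

Compound 4 `COc1cccc(-c2csc(N)c2C(=O)c2ccc(Cl)cc2)c1` is not yet measured. It differs from compound 2 in one place: methoxy in place of trifluoromethyl on an aromatic carbon.

Among the measured compounds shown here, no measured step swaps one group for another on the ring that carries the trifluoromethyl, so nothing directly bears on this change. For the measured compounds named here, the only measured step, a number 19 percentage points lower from compound 1 to compound 2 (beyond the scatter), concerns the other ring and is modest. Compound 3 carries a different small group on the first ring, and its value sits within the scatter of compound 2, which suggests that this ring tolerates exchange without a large shift. The step from compound 2 to compound 4 in this assay is therefore expected to stay within the scatter, with no clear direction, as a number 4 percentage points lower from compound 2 to compound 4 (within the scatter) expresses. Compound 4 is estimated to give about 60%, between 40% and 80%.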

Compound 4, a percentage reported as activity, at one concentration (the size of the read-out at that concentration, not a potency): 58%
Estimate against measurement, compound 4: 2 percentage points above, and the stated range covers the measured number.
By their numbers in this assay, from the lowest: compounds 4, 3 and 2 (each within the scatter of the next); then compound 1.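

In this assay, among these compounds, this is the first exchange measured at this place on the aromatic ring, and it gives a number 6 percentage points lower from compound 2 to compound 4 (within the scatter), so compound 2 and compound 4 cannot be told apart. The change is not a trivial one on paper: methoxy has 2 heavy atoms where trifluoromethyl has 4, and it brings 1 hydrogen-bond acceptor where trifluoromethyl has none, yet at this single test concentration neither difference shows up as a separable shift in the read-out. No measurement is available to explain why these two groups cannot be separated here.

The compounds shown leave open whether a more different group at this place, such as an amine or a carboxylic acid, would also stay within the scatter of compound 2, and whether the same exchange would give a similar result with hydrogen in place of the chloro on the other ring, as in compound 1. Because each number is the size of the effect at one concentration, they also leave open whether compound 2 and compound 4 would match in potency.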